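A few compounds are considered here, and "the series" means these few. Any claim that something is new, unique, unknown or untested is made for them only; others in the source may bear on it.

Measured so far in an assay on HEK293 cells for displacement of a labelled ligand from NPC1-like intracellular cholesterol transporter 1 (Homo sapiens); a higher number here means a weaker inhibitor, a lower number a stronger inhibitor:
Compound 1 `CC(C)(C)c1ccc(C(=O)N2CCC3(CC2)C(=O)N(CC(=O)NCCCN)CN3c2ccccc2)cc1` gives 4200 nM.
Compound 2 `CC(C)(C)c1ccc(C(=O)N2CCC3(CC2)C(=O)N(CC(=O)NCNS(C)(=O)=O)CN3c2ccccc2)cc1` gives 3200 nM.
Compound 3 `CCOC(=O)C1CCCN(C(=O)CN2CN(c3ccccc3)C3(CCN(C(=O)c4ccc(C(C)(C)C)cc4)CC3)C2=O)C1` gives 8200 nM.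

Compound 3 holds the highest of the three numbers, although a 2.0-fold higher number from compound 1 to compound 3 (0.29 log units; within the scatter) keeps that gap within the scatter, whereas a 2.6-fold higher number from compound 2 to compound 3 (0.41 log units; beyond the scatter) lies beyond it. Compound 4 `CC(C)(C)c1ccc(C(=O)N2CCC3(CC2)C(=O)N(CC(=O)N2CCCC(C(N)=O)C2)CN3c2ccccc2)cc1` differs from compound 3 by amino in place of ethoxy on a carbonyl carbon. Going by the values given here, no measured step exchanges exactly these two groups; the nearest guides are the steps that replaced the whole group on that carbonyl carbon, a 2.0-fold higher number from compound 1 to compound 3 (0.29 log units; within the scatter) and a 2.6-fold higher number from compound 2 to compound 3 (0.41 log units; beyond the scatter), where the partners carrying a hydrogen-bond donor gave the lower numbers. As the entering amino is counted as a donor, compound 4 is expected to show a modest lowering in this assay, a 1.5-fold lower number from compound 3 to compound 4 (0.17 log units; within the scatter), possibly still within the scatter. Compound 4 is estimated at 5500 nM, ranging from 2500 nM to 12000 nM.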

Compound 4, half-maximal inhibitory concentration: 16900 nM
For compound 4 the middle estimate is 3.1-fold (0.49 log units) below the measured one, outside the stated range (above it).
By their numbers in this assay, from the lowest: compounds 2, 1 and 3 (each within the scatter of the next, the first and the last beyond it); then compound 4.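

In this assay, amino in place of ethoxy on a carbonyl carbon raises the number (a 2.1-fold higher number from compound 3 to compound 4 (0.31 log units; beyond the scatter)), so the hydrogen-bond donor entering here brings no gain. The 3-carbamoylpiperidin-1-yl group also sits clearly behind the two other groups on that carbonyl carbon (a 5.3-fold higher number from compound 2 to compound 4 (0.72 log units; beyond the scatter); a 4.0-fold higher number from compound 1 to compound 4 (0.60 log units; beyond the scatter)), whereas compound 3 stayed within the scatter of compound 1. Nothing available explains this rise. Still open, going by these compounds, is how hydroxy, which would give a carboxylic acid, or methylamino would read on that carbonyl carbon, and so whether the rise belongs to amino itself.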